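Urea aryl swap on a pyrazole-based growth inhibitor

The compounds below may be only part of what the source reports. "The series", "measured", "known", "first", "only" and "open" are said of these compounds alone.

Measured so far:
Compound 1, `O=C(Nc1cccc(-n2cc(-c3ccncc3)c(-c3ccc(Cl)c(O)c3)n2)c1)Nc1cccc(C(F)(F)F)c1`: 15800 nM
Compound 2, `COc1cc(-c2nn(-c3cccc(NC(=O)Nc4cc(C(F)(F)F)cc(C(F)(F)F)c4)c3)cc2-c2ccncc2)ccc1Cl`: 2430 nM

Of the compounds shown here, two sharing a common core have been measured in a functional assay on SF-268 cells (Homo sapiens) for inhibition, read by sulforhodamine B assay, with a stated time of 48 h; a higher number here means a weaker inhibitor of growth, a lower number a stronger inhibitor of growth. Compound 1 gives 15800 nM, the higher of the two numbers, so it stands as the weaker inhibitor of growth in this assay. For the measured compounds named here, compound 2 gives 2430 nM, a number that lies beyond the usual scatter below that of compound 1; compound 2 differs from compound 1 in more than one place, so the two values show only that this pair spans a clear gap.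

Compound 3, `O=C(Nc1cccc(-n2cc(-c3ccncc3)c(-c3ccc(Cl)c(O)c3)n2)c1)Nc1ccc(Cl)c(Cl)c1`, has not yet been measured. It differs from compound 1 in a single place: 3,4-dichlorophenyl in place of 3-(trifluoromethyl)phenyl on an amide-type nitrogen. Going by the values given here, no single-point step between measured compounds is available to calibrate this change. Among the compounds with values here, the only guidance is that compound 2, which carries a different urea aryl group, reaches 2430 nM, so a modest step downward, toward stronger inhibition of growth, is expected for compound 3, though a step within the scatter would not surprise. The estimated step from compound 1 to compound 3 in this assay is a 2.0-fold lower number from compound 1 to compound 3 (0.30 log units; within the scatter). Compound 3 is expected to give about 8000 nM, with a plausible range from 2500 nM to 25000 nM.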

Compound 3, concentration for total growth inhibition: 10900 nM
Beside the measured number, compound 3's estimate is 1.4-fold (0.13 log units) below it; low and high end bracket the measured number.
By their numbers in this assay, from the lowest: compound 2; then compounds 3 and 1 (each within the scatter of the next).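

In this assay, putting 3,4-dichlorophenyl in place of 3-(trifluoromethyl)phenyl on an amide-type nitrogen gives a 1.4-fold lower number from compound 1 to compound 3 (0.16 log units; within the scatter). For the compounds shown here, this is the first comparison that isolates this position, since compounds 1 and 2 differ in more than one place, and it shows that these two aryl groups cannot be told apart in this assay, even though one carries two chlorine atoms and the other a trifluoromethyl group. No measurement shown here offers an explanation for how closely the two compounds read.

The gap between compound 1 and compound 2 remains unassigned, as their values alone cannot show how much of it belongs to the urea aryl group and how much to the other place where the two compounds differ. Going by these compounds, it also remains open whether an aryl group on this nitrogen carrying an amine or a carboxylic acid, rather than only halogen or trifluoromethyl substituents, would shift the number beyond the usual scatter.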